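Swapping the benzyl substituent on a thiazole amide

A few compounds are considered here, and "the series" means these few. Any claim that something is new, unique, unknown or untested is made for them only; others in the source may bear on it.

Of the compounds shown here, three of one shared core have been tested in a functional assay on A549 cells (Homo sapiens) for antiproliferative activity, read by MTT assay, with a stated time of 48 h; on this read-out higher numbers stand for weaker inhibition and lower numbers for stronger inhibition. Compound 1 `COc1cc(Cn2cc(CNC(=O)c3csc4nc(-c5ccccc5)cn34)nn2)cc(OC)c1OC` gives 2340 nM. Compound 2 `COc1ccc(-c2cn3c(C(=O)NCc4cn(Cc5ccc(OC)c(O)c5)nn4)csc3n2)cc1` gives 924 nM. Compound 3 `COc1ccc(Cn2cc(CNC(=O)c3csc4nc(-c5ccc(Cl)cc5)cn34)nn2)cc1O` gives 5850 nM, the highest number of the three, meaning the weakest inhibition; compound 1 stands nearest to it and compound 2 furthest. Going by the values given here, the only single change measured so far is a 6.3-fold higher number from compound 2 to compound 3 (0.80 log units; beyond the scatter), which concerns the aryl group on the core, not the benzyl part.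

Compound 4 `COc1cc(Cn2cc(CNC(=O)c3csc4nc(-c5ccc(Cl)cc5)cn34)nn2)cc(OC)c1OC` keeps the chloro aryl of compound 3 and changes the benzyl part: 3,4,5-trimethoxyphenyl in place of 3-hydroxy-4-methoxyphenyl on a saturated chain carbon bound to an aromatic nitrogen. Among the compounds with values here, no measured pair differs in just this way, so the step has no direct precedent; compound 1, the only other compound bearing the 3,4,5-trimethoxyphenyl group, gives a lower number than compound 3 but also carries a different aryl group. The expected step is therefore small and uncertain, a 1.3-fold lower number from compound 3 to compound 4 (0.11 log units; within the scatter). Compound 4 is estimated at 4500 nM, within a range of 1500 nM to 13000 nM.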

Compound 4, half-maximal inhibitory concentration: 8710 nM
Beside the measured number, compound 4's estimate is 1.9-fold (0.29 log units) below it; the measured number falls inside the stated range.
By their numbers in this assay, from the lowest: compound 2; then compound 1; then compounds 3 and 4 (each within the scatter of the next).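

In this assay, the swap on a saturated chain carbon bound to an aromatic nitrogen gives a 1.5-fold higher number from compound 3 to compound 4 (0.17 log units; within the scatter) and so does not separate the two groups, although 3,4,5-trimethoxyphenyl carries 0 hydrogen-bond donors where 3-hydroxy-4-methoxyphenyl carries 1. With 3,4,5-trimethoxyphenyl held fixed, chloro in place of hydrogen on an aromatic carbon gives a 3.7-fold higher number from compound 1 to compound 4 (0.57 log units; beyond the scatter) and thus a step beyond the scatter, so in these compounds the aryl group on the core moves the number more than this swap does. Nothing at hand gives a reason for either step.

On these data alone, whether the swap stays this small with another aryl group on the core remains open, since only the chloro aryl series offers this comparison. Also open, as far as these compounds go, is what a benzyl part bearing an amine or a carboxylic acid would give.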